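This account rests on a few compounds, and the source may have more. Where it says the series, first, only, none or still open, it means among the compounds named here.

Within the data shown here, compound 2 `O=C(c1cccc(F)c1)N1CCn2nc(-c3ccc(F)cn3)cc2C1` is one of only two compounds measured in a functional assay on HEK293 cells for negative allosteric modulation of metabotropic glutamate receptor 5 (Homo sapiens), read by calcium flux, with a stated time of 20 min (on this read-out lower numbers stand for stronger inhibition and higher numbers for weaker inhibition), where compound 2 gives 257 nM. Among the measured compounds shown here, its single neighbour is compound 1 `O=C(c1cccc(Cl)c1)N1CCn2nc(-c3ccc(F)cn3)cc2C1`, which in this assay gives 150 nM; the step of a 1.7-fold higher number from compound 1 to compound 2 (0.23 log units; within the scatter) keeps the two within the scatter. Compound 3 `Cc1cccc(C(=O)N2CCn3nc(-c4ccc(F)cn4)cc3C2)c1` differs from compound 2 by methyl in place of fluoro on an aromatic carbon. For the measured compounds named here, the one measured step, a 1.7-fold higher number from compound 1 to compound 2 (0.23 log units; within the scatter), swaps one halogen for another and offers no direct guide for a methyl, so in this assay a slightly lower number, hardly beyond the scatter, is expected. Compound 3 is therefore estimated at 180 nM, between 80 nM and 400 nM. That estimate amounts to a 1.4-fold lower number from compound 2 to compound 3 (0.15 log units; within the scatter).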

Compound 3, half-maximal inhibitory concentration: 150 nM
Compound 3: the middle estimate sits 1.2-fold (0.08 log units) above what was measured, and the stated range covers the measured number.
By their numbers in this assay, from the lowest: compounds 1, 3 and 2 (each within the scatter of the next).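

In this assay the place meta to a large group takes a methyl as readily as either halogen: the step of a 1.7-fold lower number from compound 2 to compound 3 (0.23 log units; within the scatter) and the step of no change at the digits printed from compound 1 to compound 3 (within the scatter) both lie within the scatter. A carbon group at this place therefore reads the same as chloro and fluoro across these three compounds. Nothing available explains why these three groups read alike.

Going by these compounds, whether methoxy, trifluoromethyl, an amine or a carboxylic acid at this place would also stay within the scatter remains open. So does whether methyl would read the same elsewhere on this ring.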